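Ring Amine in Place of Open Chain Amine at the Core

The source may hold more compounds than are shown below. What is called first, only, known or untested is meant among the compounds shown, and "the series" means these compounds.

Measured so far:
Compound 1 `CCCCN(CC)Cc1c(C(F)(F)F)nc2n(-c3c(C)cc(C)cc3C)c(Cl)cn12`: 78 nM
Compound 2 `Cc1cc(C)c(-n2c(Cl)cn3c(CN(CCC(F)(F)F)Cc4ccc(F)cc4)c(C(F)(F)F)nc23)c(C)c1`: 34 nM

In an assay on cells for displacement of a labelled ligand from corticotropin-releasing factor receptor 1 (Homo sapiens), with a stated time of 100 min (on this read-out higher numbers stand for weaker inhibition and lower numbers for stronger inhibition), compound 1 gives 78 nM. For the measured compounds named here, this is the higher of the two numbers known; compound 2 gives 34 nM, a lower number by a gap that lies beyond the scatter, so compound 2 inhibits more strongly. Going by the values given here, no single-change step between measured compounds is known, so nothing here tells how an exchange at the amine side chain shifts the read-out.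

Compound 3 `Cc1cc(C)c(-n2c(Cl)cn3c(CN4CCCC(C)C4)c(C(F)(F)F)nc23)c(C)c1` is the unmeasured compound. It differs from compound 1 by 3-methylpiperidin-1-yl in place of butyl(ethyl)amino on a saturated chain carbon bound to an aromatic carbon, so a ring takes the place of an open chain of the same size, with the acceptor count unchanged. Without any measured step of this kind, a change of modest size is expected, in either direction. Compound 3 is estimated at 100 nM in this assay, within 30 nM to 350 nM, which means an expected step of a 1.3-fold higher number from compound 1 to compound 3 (0.11 log units; within the scatter).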

Compound 3, inhibition constant: 5800 nM
Estimate against measurement, compound 3: 58-fold (1.76 log units) below; the whole stated range lies below it.
By their numbers in this assay, from the lowest: compound 2; then compound 1; then compound 3.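

In this assay, this first single-change step at the position is large: a 74-fold higher number from compound 1 to compound 3 (1.87 log units; beyond the scatter) when 3-methylpiperidin-1-yl takes the place of butyl(ethyl)amino. The two groups have the same heavy atoms and the same counts of hydrogen-bond donors and acceptors, so those counts alone do not set the read-out here, and inhibition still weakens sharply when the open chain gives way to this methyl-bearing ring. No available evidence bears on the reason for this loss.

With only one ring amine shown, it remains open whether the ring or its methyl group goes with the weaker inhibition. Piperidin-1-yl without the methyl group would separate these two features, while pyrrolidin-1-yl would show how a smaller ring behaves at this position.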